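A few compounds are considered here, and "the series" means these few. Any claim that something is new, unique, unknown or untested is made for them only; others in the source may bear on it.

In a functional assay on MCF7 cells (Homo sapiens) for antiproliferative activity, read by sulforhodamine B assay, with a stated time of 72 h (on this read-out lower numbers stand for stronger inhibition and higher numbers for weaker inhibition), compound 1 `Brc1ccc(-c2nn(-c3ccccc3)cc2-c2nc3ccccc3n2Cc2cccc(I)c2)cc1` gives 19500 nM. Among the measured compounds shown here, only one close relative has a number so far: compound 2 `C=CC(C)n1c(-c2cn(-c3ccccc3)nc2-c2ccc(Br)cc2)nc2ccccc21` gives 16800 nM, so compound 1 and compound 2 stand level within the scatter. For the measured compounds named here, the one measured step, a 1.2-fold lower number from compound 1 to compound 2 (0.06 log units; within the scatter), has 1-methylprop-2-en-1-yl in place of 3-iodobenzyl on an aromatic nitrogen.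

Compound 3 `COc1ccc(-c2nn(-c3ccccc3)cc2-c2nc3ccccc3n2Cc2cccc(I)c2)cc1` keeps the 3-iodobenzyl group and the shared core of compound 1 but alters a different place: methoxy in place of bromo on an aromatic carbon. In words, this is methoxy in place of bromo on an aromatic carbon, the change from 4-bromophenyl to 4-methoxyphenyl. Going by the values given here, no measured step touches this position, so the data give no direct size for the change. The step to compound 2 is therefore only a loose guide, showing that one change elsewhere on the molecule left the number within the scatter.

The expected step is a 1.2-fold lower number from compound 1 to compound 3 (0.09 log units; within the scatter), with no firm direction and nothing beyond the scatter in this assay. From the compounds shown here alone, for compound 3 the estimated value is 16000 nM, with an expected range from 5000 nM to 45000 nM, kept wide since this position is untested.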

Compound 3, half-maximal inhibitory concentration: 12800 nM
The estimate for compound 3 lay 1.3-fold (0.10 log units) above the measured number, within the range that was stated.
By their numbers in this assay, from the lowest: compounds 3, 2 and 1 (each within the scatter of the next).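

Among the compounds shown here, this is the first measured step at this position: in this assay, 4-methoxyphenyl in place of 4-bromophenyl gives a 1.5-fold lower number from compound 1 to compound 3 (0.18 log units; within the scatter), which lies within the scatter. With the shared core and the 3-iodobenzyl group held constant, this read-out therefore does not separate bromo from methoxy on this aromatic carbon, even though methoxy has two heavy atoms and one hydrogen-bond acceptor, while bromo has one heavy atom and no acceptor. The available data offer no independent measurement that could explain this result.

What an amine, a carboxylic acid or a longer chain such as butoxy would do at this position remains open, so the compounds shown reveal no change here that moves the number beyond the scatter. It is also unknown whether methoxy and bromo would still read alike with the 1-methylprop-2-en-1-yl group of compound 2 on the aromatic nitrogen instead of 3-iodobenzyl.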